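The source may report more compounds than this note shows. Statements on the series, on what has been measured and on what is new or still open speak of the compounds shown alone.

Working notes on the series, read in a functional assay on A549 cells (Homo sapiens) for antiproliferative activity, read by MTT assay, with a stated time of 72 h; a higher number here means a weaker inhibitor, a lower number a stronger inhibitor. Compound 1 `CN1CCN(c2ccc(Nc3ncc4nc(Sc5ccccc5)n(C5CCOCC5)c4n3)cc2)CC1` gives 2950 nM. Compound 2 `CN1CCN(c2ccc(Nc3ncc4nc(Sc5ccccc5)n(C5CCCC5)c4n3)cc2)CC1` gives 237 nM, the lower of the two actual numbers in hand. Compound 3 `CN(C)C1CCN(c2ccc(Nc3ncc4nc(Sc5ccccc5)n(C5CCOCC5)c4n3)cc2)CC1` reports only a limit, > 10000 nM.

Compound 4 `CN1CCN(c2ccc(Nc3ncc4nc([S+]([O-])c5ccccc5)n(C5CCCC5)c4n3)cc2)CC1` differs from compound 2 in one place: a group of 8 heavy atoms (6 carbon, 1 oxygen, 1 sulfur; one six-membered aromatic ring of carbon only) in place of a group of 7 heavy atoms (6 carbon, 1 sulfur; one six-membered aromatic ring of carbon only), on an aromatic carbon. Phenylsulfanyl leaves, and the new group sits on an aromatic carbon of a five-membered aromatic ring with 2 nitrogen, between two ring nitrogen atoms.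

Among the measured compounds shown here, no measured step touches this place, so the two available steps bear only indirectly. Cyclopentyl in place of oxan-4-yl gave a 12-fold lower number from compound 1 to compound 2 (1.10 log units; beyond the scatter), a large step. 4-(dimethylamino)piperidin-1-yl in place of 4-methylpiperazin-1-yl gave an at least 3.3-fold higher number from compound 1 to compound 3 (0.53 log units; beyond the scatter), a step of at least modest size. Both show that single changes can move this series beyond the scatter, and the higher number is the direction expected here, at a moderate size with wide uncertainty. The expected change is a 3.0-fold higher number from compound 2 to compound 4 (0.47 log units; beyond the scatter). Compound 4 is estimated at 700 nM, with an expected range from 150 nM to 3500 nM.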

Compound 4, half-maximal inhibitory concentration: > 10000 nM
Compound 4 gave a limit, no number; the forecaster's own chance of this, stated with the estimate: 5%; at least 14-fold (1.15 log units) between middle value and limit.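

In this assay, among the compounds shown here, the first change at this position, on the aromatic carbon between two ring nitrogen atoms, gives an at least 42-fold higher number from compound 2 to compound 4 (1.62 log units; beyond the scatter), so this place is at least as sensitive as the two places already probed. As far as these compounds go, the reading for compound 4 is a limit and not a number, so the full size of the loss stays unknown, and the cyclopentyl group that marks compound 2 does not preserve activity once phenylsulfanyl leaves. Compound 4 sits at the same limit as compound 3: the limit of > 10000 nM in this assay, at which 2 of the 4 values shown sit.

Only one replacement at this position is shown, so it remains open whether any other group is tolerated here, such as a phenyl ring attached through an amine nitrogen or an ether oxygen. Also open, from the compounds shown here alone, is whether the same change costs as much alongside oxan-4-yl.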